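This account rests on a few compounds, and the source may have more. Where it says the series, first, only, none or still open, it means among the compounds named here.

Measured so far:
- compound 1 `CC(C)=CCCC1=CC[C@H](C(=O)NCCC(=O)O)[C@@H](c2ccccc2)C1`: in an assay on isolated protein for inhibition of Apoptosis regulator Bcl-2 (Homo sapiens), read by fluorescence polarization, with stated times of 5 min and 10 min (on this read-out lower numbers stand for stronger inhibition and higher numbers for weaker inhibition), compound 1 gives > 23000 nM, which is a limit of the assay and not a number.
- compound 2 `COC(=O)c1ccc(NC(=O)[C@@H]2CC=C(CCC=C(C)C)C[C@H]2c2ccccc2)cc1`: in this assay compound 2 gives > 23000 nM, likewise a limit and not a number.

Within the data shown here, compound 1 therefore stands at the limit, and the only other value shown sits there too (the limit of > 23000 nM in this assay, at which 2 of the 2 values shown sit). Among the measured compounds shown here, no step between two measured compounds can be read from the numbers, as neither of them is a number.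

Compound 3 `CC(C)=CCCC1=CC[C@H](C(N)=O)[C@@H](c2ccccc2)C1` is the next member to be run in this assay. It differs from compound 1 in one place: hydrogen in place of 2-carboxyethyl on an amide-type nitrogen. The amide is thus left unsubstituted, the 2-carboxyethyl gone.

For the measured compounds named here, because both values shown sit at the limit of > 23000 nM in this assay, at which 2 of the 2 values shown sit, there is no measured step on which to base a direction for this change. The expectation is a step that the limit leaves unreadable from compound 1 to compound 3 in this assay, that is none beyond the usual scatter. Compound 3 is accordingly estimated at 35000 nM, with a range from 10000 nM to 120000 nM, and most probably the assay will again report only a limit.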

Compound 3, inhibition constant: > 23000 nM
Compound 3: only a limit was reported; the forecaster's own chance of this, stated with the estimate: 85%; the middle value is on the limit's open side.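

No step can be read from compound 1 to compound 3, since both results are limits of the assay and not numbers: the limit of > 23000 nM in this assay, at which 3 of the 3 values shown sit.

The compounds shown leave open whether any member of this series gives a readable value in this assay, and so what the exchange of 2-carboxyethyl for hydrogen on the amide-type nitrogen does to inhibition.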